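Taking the benzyl off an inactive adenine nucleoside

This account rests on a few compounds, and the source may have more. Where it says the series, first, only, none or still open, it means among the compounds named here.

Compound 1 `Nc1ncnc2c1nc(NCc1ccc(Cl)c(Cl)c1)n2[C@@H]1O[C@H](COCc2ccccc2)[C@@H](O)[C@H]1O` carries a benzyl group on the oxygen of its sugar side chain. In a functional assay on HCT-116 cells (Homo sapiens) for cytotoxicity, read by sulforhodamine B assay (a higher number here means a weaker inhibitor of growth, a lower number a stronger inhibitor of growth), compound 1 gives > 80000 nM, which is a limit of the assay rather than a measured number. A related compound 2 `N#Cc1ccc(COC[C@H]2O[C@@H](n3c(NCc4ccc5ncccc5c4)nc4c(N)ncnc43)[C@H](O)[C@@H]2O)cc1` has been tested in this assay as well. In this assay compound 2 gives > 80000 nM, again a limit. Compound 1 therefore stands at the limit of > 80000 nM in this assay, at which 2 of the 2 values shown sit, so no real potency difference between the two can be read from the numbers. Compound 3 `COC[C@H]1O[C@@H](n2c(NCc3ccc(Cl)c(Cl)c3)nc3c(N)ncnc32)[C@H](O)[C@@H]1O` has not yet been tested. It differs from compound 1 by hydrogen in place of phenyl on a saturated chain carbon bound to an oxygen on a saturated carbon. With both measured compounds at the limit, compound 3 is expected to remain there too, so the step that the limit leaves unreadable from compound 1 to compound 3 is estimated as none beyond the scatter. For compound 3 the expected value in this assay is 100000 nM, in the range 30000 nM to 300000 nM.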

Compound 3, concentration for 50% growth inhibition: > 80000 nM
Compound 3 ended at the assay's limit; the forecaster's own chance of this, stated with the estimate: 85%; the middle value does not contradict the limit.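

Compound 1 and compound 3 both sit at the limit of the assay, so no step between them can be read: the limit of > 80000 nM in this assay, at which 3 of the 3 values shown sit.

The compounds shown leave open whether benzyl to methyl changes growth inhibition at all in this assay, and what a measurable value would look like on this core.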